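The source may report more compounds than this note shows. Statements on the series, on what has been measured and on what is new or still open speak of the compounds shown alone.

Measured so far:
compound 1 `COc1ccc(-c2cn(C[C@H]3COC(C)(C)O3)nn2)cc1`: > 100000 nM
compound 2 `COc1ccc(-c2cn(Cc3ccccc3)nn2)cc1`: > 100000 nM

Both values come from a functional assay on B16 cells (Mus musculus) for cytotoxicity, read by MTT assay, with a stated time of 48 h; a higher number here means a weaker inhibitor, a lower number a stronger inhibitor. For compound 1 the value > 100000 nM is a limit of the assay, not a number. For compound 2 the value > 100000 nM is likewise a limit. Within the data shown here, the only measured step, a step that the two limits leave unreadable from compound 1 to compound 2, therefore gives no size at all: the limit of > 100000 nM in this assay, at which 2 of the 2 values shown sit.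

Compound 3 `CC1(C)OC[C@H](Cn2cc(-c3ccc(C(F)(F)F)cc3)nn2)O1` differs from compound 1 by trifluoromethyl in place of methoxy on an aromatic carbon. Among the measured compounds shown here, no measured step touches this position; the one step known changes a different part of the shared core and is itself unreadable. There is thus no basis for expecting movement in either direction beyond the scatter. Compound 3 is therefore expected at an estimated 100000 nM, with a range from 30000 nM to 300000 nM, and most likely reported again only as a limit. The step this estimate implies, a number no higher from compound 1 to compound 3 (the limit leaves the size open), is expected to be small.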

Compound 3, half-maximal inhibitory concentration: > 100000 nM
Compound 3: no number, only a limit; the forecaster's own chance of this, stated with the estimate: 85%; the middle value lies on the limit itself.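

Among these compounds, compound 3 gives > 100000 nM in this assay, a limit and not a number, so no step between compound 1 and compound 3 can be read. The compounds shown leave open whether trifluoromethyl in place of methoxy, or any other change here, alters the read-out at all: the limit of > 100000 nM in this assay, at which 3 of the 3 values shown sit.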